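The compounds below may be only part of what the source reports. "The series", "measured", "known", "first", "only" and "open" are said of these compounds alone.

Compound 3 `OC[C@H]1OC(n2cnc3c(-c4nccs4)ncnc32)[C@H](O)[C@@H]1O` gives 16000 nM in a functional assay on L1210 cells (Mus musculus) for inhibition (a higher number here means a weaker inhibitor, a lower number a stronger inhibitor), the second highest of the three numbers measured; compound 1 `OC[C@H]1OC(n2cnc3c(-c4cc[nH]c4)ncnc32)[C@H](O)[C@@H]1O` gives 17500 nM and compound 2 `OC[C@H]1OC(n2cnc3c(-c4ccc(F)cc4)ncnc32)[C@H](O)[C@@H]1O` gives 4500 nM in this assay. Compound 4 `OC[C@H]1OC(n2cnc3c(-c4ccsc4)ncnc32)[C@H](O)[C@@H]1O` carries thiophen-3-yl in place of 1,3-thiazol-2-yl on an aromatic carbon. For the measured compounds named here, two measured steps bear on this change: a 1.1-fold lower number from compound 1 to compound 3 (0.04 log units; within the scatter) and a 3.6-fold higher number from compound 2 to compound 3 (0.55 log units; beyond the scatter), so exchanging one five-membered aromatic ring for another left this assay nearly unchanged, whereas 4-fluorophenyl gave the lowest number of the set. Thiophen-3-yl is again a five-membered aromatic ring, now with 1 hetero atom, so at most a modest step downward is expected, a 1.8-fold lower number from compound 3 to compound 4 (0.25 log units; within the scatter). Compound 4 is accordingly estimated at 9000 nM, with a range from 3500 nM to 22000 nM.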

Compound 4, half-maximal inhibitory concentration: 10800 nM
Compound 4: middle estimate off by 1.2-fold (0.08 log units), on the low side, within the range that was stated.
By their numbers in this assay, from the lowest: compound 2; then compounds 4, 3 and 1 (each within the scatter of the next).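

Thiophen-3-yl, with sulfur as its only ring hetero atom, stays within the scatter of both other five-membered rings in this assay (a 1.5-fold lower number from compound 3 to compound 4 (0.17 log units; within the scatter) and a 1.6-fold lower number from compound 1 to compound 4 (0.21 log units; within the scatter)), so the ring hetero atoms in compounds 1, 3 and 4 give no order here. 4-Fluorophenyl remains apart from this third five-membered ring too (a 2.4-fold higher number from compound 2 to compound 4 (0.38 log units; beyond the scatter)). No measured evidence accounts for that gap.

Still open, as far as these compounds go, is whether the gap follows the fluorine or the six-membered ring, which unsubstituted phenyl would separate. From the compounds shown here alone, how an amine or a longer alkyl chain behaves on this carbon is also open.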